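The source may hold more compounds than are shown below. What is called first, only, known or untested is meant among the compounds shown, and "the series" means these compounds.

Three compounds of a shared core have been run in a functional assay, with a stated time of 150 min, tested at 25 ug/mL (on this read-out higher numbers stand for a stronger effect at the one concentration tested and lower numbers for a weaker effect), and only one of them gives a number. Compound 1, with the structure `COC(=O)c1c(Nc2ccc(C)cc2)sc(C(=O)c2ccc(C)cc2)c1C`, is reported in this assay as "not active" (no number reported). Compound 2, with the structure `COc1ccc(C(=O)c2sc(Nc3ccc(C)cc3)c(C(=O)O)c2C)cc1`, is likewise reported in this assay as "not active" (no number reported). Compound 3, with the structure `Cc1ccc(C(=O)c2sc(Nc3ccccc3)c(C(=O)O)c2C)cc1`, is the one that carries a figure: in this assay compound 3 gives 4.35%, a small effect at the single concentration tested, and since compound 1 and compound 2 have no figure beside them, compound 3 stands alone as the only measured point.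

The next compound, compound 4, has the structure `Cc1ccc(Nc2sc(C(=O)c3ccc(C)cc3)c(C)c2C(=O)O)cc1`. It differs from compound 3 in one place: methyl in place of hydrogen on an aromatic carbon.

Within the data shown here, no step between two measured compounds has been recorded, so there is nothing to set the size of this change against. The read-out for compound 3 is already small, and a single added methyl is not expected to move it far. The step from compound 3 to compound 4 is estimated at a number 0.4 percentage points lower from compound 3 to compound 4 (within the scatter), that is, no change beyond the usual scatter. Compound 4 is accordingly expected to give about 4% in this assay, within a range of 0% to 12%.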

Compound 4, a percentage reported as activity, at one concentration (the size of the read-out at that concentration, not a potency): "not active" (no number reported)
Compound 4 has no reported number here; no gap can be computed for the estimate.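

In this assay compound 3 gives 4.35% and compound 4 is reported as "not active" (no number reported), so no step can be read between compound 3 and compound 4. Nothing shown here bears on this result. The compounds shown leave open whether going from phenyl to 4-methylphenyl changes the effect at all, and by how much.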